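This account rests on a few compounds, and the source may have more. Where it says the series, first, only, none or still open, it means among the compounds named here.

Measured so far:
compound 1, `COC(=O)c1cccc(-c2cnc(C(=O)CCCCCCc3ccccc3)s2)n1`, > 100000 nM
compound 2, `COC(=O)c1cccc(-c2ccc(C(=O)CCCCCCc3ccccc3)nn2)n1`, 10000 nM

In an assay for inhibition of Fatty-acid amide hydrolase 1 (Rattus norvegicus) (on this read-out higher numbers stand for weaker inhibition and lower numbers for stronger inhibition), compound 1 gives > 100000 nM, which is a limit of the assay and not a number. In this assay compound 2 gives 10000 nM, the only number among the two results shown. Compound 2 therefore stands alone as the one quantified result, while the other result rests at the limit of > 100000 nM in this assay, at which 1 of the 2 values shown sits.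

Compound 3, `N#Cc1cccc(-c2ccc(C(=O)CCCCCCc3ccccc3)nn2)n1`, is not yet measured in this assay. It differs from compound 2 in one place: cyano in place of methoxycarbonyl on an aromatic carbon, in words a cyano in place of a methoxycarbonyl on an aromatic carbon. Going by the values given here, no step between two measured compounds is available to set the scale for this change, so the expectation rests on compound 2 and the nature of the swap alone. The change expected a 2.0-fold lower number from compound 2 to compound 3 (0.30 log units; within the scatter) is estimated to be a small move toward stronger inhibition, not clearly beyond the usual scatter. Compound 3 is thus expected to give about 5000 nM in this assay, with a likely range from 1000 nM to 30000 nM.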

Compound 3, half-maximal inhibitory concentration: 13000 nM
The estimate for compound 3 lay 2.6-fold (0.41 log units) below the measured number, and the stated range covers the measured number.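

Going by these compounds alone, the step from methoxycarbonyl to cyano gives the first reading of how much this position matters. It lies on an aromatic carbon of a six-membered aromatic ring with 1 nitrogen, next to the ring nitrogen and meta to a large group. In this assay, the swap gives a 1.3-fold higher number from compound 2 to compound 3 (0.11 log units; within the scatter), so the two groups cannot be told apart on this read-out, even though cyano has 2 heavy atoms and 1 hydrogen-bond acceptor where methoxycarbonyl has 4 heavy atoms and 2 hydrogen-bond acceptors. The methoxycarbonyl group as such is therefore not needed to reach this level of inhibition, and nothing shown here explains why the two groups read alike.

From the compounds shown here alone, whether this insensitivity extends to other groups at the same position, such as an amine, a carboxylic acid or a primary amide, remains open. Going by these compounds, it is also open whether the same swap would read the same way with a longer chain on the carbonyl or on another core.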